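Capping group swap on the trimethyllysine peptide series

The source may hold more compounds than are shown below. What is called first, only, known or untested is meant among the compounds shown, and "the series" means these compounds.

For the measured compounds named here, compound 1 `CC(C)C[C@H](NC(=O)[C@H](C)NC(=O)CCc1ccccc1)C(=O)N[C@@H](CCCC[N+](C)(C)C)C(=O)N[C@@H](CO)C(N)=O` holds the lower of the two numbers so far: in an assay on isolated protein for displacement of a labelled ligand from Chromobox protein homolog 7 (Homo sapiens), read by fluorescence polarization, with a stated time of 15 min (a lower number here means a stronger inhibitor, a higher number a weaker inhibitor), compound 1 gives 26000 nM, while compound 2 `CC(C)C[C@H](NC(=O)[C@H](C)NC(=O)CNS(=O)(=O)c1ccc(C(=O)O)cc1)C(=O)N[C@@H](CCCC[N+](C)(C)C)C(=O)N[C@@H](CO)C(N)=O` gives 53000 nM in this assay, a gap beyond the usual scatter. Compound 3 `CC(C)C[C@H](NC(=O)[C@H](C)NCc1ccc(C(=O)O)cc1)C(=O)N[C@@H](CCCC[N+](C)(C)C)C(=O)N[C@@H](CO)C(N)=O` differs from compound 1 only at the cap, (4-carboxybenzyl in place of phenethylcarbonyl on an amine nitrogen). Going by the values given here, no measured pair reports this particular change, so the expected step from compound 1 to compound 3, a 1.5-fold higher number from compound 1 to compound 3 (0.19 log units; within the scatter), is a modest weakening at most, near the edge of the scatter. Compound 3 is estimated at 40000 nM in this assay, with a range of 15000 nM to 120000 nM.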

Compound 3, half-maximal inhibitory concentration: > 2000000 nM
Compound 3: no number, only a limit; the forecaster's own chance of this, stated with the estimate: 20%; middle value at least 50-fold (1.69 log units) away from the limit.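

Two caps with the same count of heavy atoms and one six-membered aromatic ring each are far from interchangeable on this nitrogen: 4-carboxybenzyl in place of phenethylcarbonyl gives an at least 76-fold higher number from compound 1 to compound 3 (1.88 log units; beyond the scatter). The carboxylic acid alone does not account for this, as compound 2 also carries one and gives 53000 nM. The entry for compound 3 is a limit, not a number: the limit of > 2000000 nM in this assay, at which 1 of the 3 values shown sits.

The compounds shown leave open whether the loss follows the carboxylic acid on this particular cap or the change from amide to amine at the nitrogen. An unsubstituted benzyl cap or a 4-carboxybenzoyl cap would separate the two.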